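The source may hold more compounds than are shown below. What is called first, only, known or untested is meant among the compounds shown, and "the series" means these compounds.

Of the compounds shown here, three built on one shared core have been measured in an assay on microsomes for inhibition of Amine oxidase [flavin-containing] B (Homo sapiens), read by fluorescence and spectrophotometry, with a stated time of 20 min; a higher number here means a weaker inhibitor, a lower number a stronger inhibitor. Compound 1 `O=c1ccoc2ccc(OCCCc3ccccc3)cc12` gives 57 nM. Compound 2 `O=c1ccoc2ccc(OCc3cccc(Cl)c3)cc12` gives 3.6 nM. Compound 3 `O=c1ccoc2ccc(OCc3ccc(Br)cc3)cc12` gives 3.3 nM, the lowest of the three numbers; its gap to compound 2 lies within the usual scatter of repeated measurements, so those two cannot be told apart, while its gap to compound 1 lies well beyond that scatter.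

Compound 4 `O=c1ccoc2ccc(OCc3ccc(C(F)(F)F)cc3)cc12` has not yet been measured. It differs from compound 3 in a single change, (trifluoromethyl in place of bromo on an aromatic carbon), on an aromatic carbon of a six-membered aromatic ring of carbon only, para to a large group. For the measured compounds named here, no measured pair in this set shows this exact exchange, so there is no direct precedent for its size or direction. Since compound 2 and compound 3 sit so close together, the expectation is that compound 4 will also stay near them. The step from compound 3 to compound 4 is estimated as a 1.5-fold higher number from compound 3 to compound 4 (0.18 log units; within the scatter), a change not clearly beyond the scatter. For compound 4 the estimate in this assay is 5 nM, with a range from 1.5 nM to 16 nM.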

Compound 4, half-maximal inhibitory concentration: 2 nM
For compound 4 the middle estimate is 2.5-fold (0.40 log units) above the measured one, and the stated range covers the measured number.
By their numbers in this assay, from the lowest: compounds 4, 3 and 2 (each within the scatter of the next); then compound 1.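

In this assay putting trifluoromethyl in place of bromo on this aromatic carbon, para to a large group, gives a 1.7-fold lower number from compound 3 to compound 4 (0.22 log units; within the scatter) and so leaves the two compounds indistinguishable. For the compounds shown here, the position therefore accepts a group of 4 heavy atoms as readily as one of 1 heavy atom, with no loss that can be seen, which the earlier compounds did not show. No measurement at hand explains why the two groups behave alike.

Still open, as far as these compounds go, is what an amine, a carboxylic acid or a nitrile would do on this same carbon, since these differ from both groups tested so far. Also open, from the compounds shown here alone, is whether trifluoromethyl would give a similar result on the longer chain that compound 1 carries.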